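Replacing a Pyridine Arm with a Sulfone Ring

The compounds below may be only part of what the source reports. "The series", "measured", "known", "first", "only" and "open" are said of these compounds alone.

Compound 1 `c1cncc(CNCCCCN(C[C@H]2Cc3ccccc3CN2)[C@H]2CCCc3cccnc32)c1` is the reference point of this small set. In a functional assay on cells for antagonist activity at C-X-C chemokine receptor type 4 (Homo sapiens), read by fluorescence and calcium flux, with stated times of 25 min and 90 s (a higher number here means a weaker inhibitor, a lower number a stronger inhibitor), compound 1 gives 15.3 nM, the lowest number of the three measured compounds. Compound 2 `c1ccc2c(c1)CN[C@@H](CN(CCCCNCC1CCNCC1)[C@H]1CCCc3cccnc31)C2` gives 36.5 nM and compound 3 `c1ccc2c(c1)CN[C@@H](CN(CCCCNCC1CCSCC1)[C@H]1CCCc3cccnc31)C2` gives 69.6 nM. The two steps away from compound 1 both raise the number: a 2.4-fold higher number from compound 1 to compound 2 (0.38 log units; beyond the scatter) and a 4.5-fold higher number from compound 1 to compound 3 (0.66 log units; beyond the scatter). Between the two saturated rings the gap is small, a 1.9-fold higher number from compound 2 to compound 3 (0.28 log units; within the scatter).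

Compound 4 `O=S1(=O)CCC(CNCCCCN(C[C@H]2Cc3ccccc3CN2)[C@H]2CCCc3cccnc32)CC1` carries the change (1,1-dioxothian-4-yl in place of pyridin-3-yl on a saturated chain carbon bound to an amine nitrogen). Since both earlier swaps of the pyridin-3-yl for a saturated six-membered ring weakened inhibition modestly, a similar step is expected here, a 3.9-fold higher number from compound 1 to compound 4 (0.59 log units; beyond the scatter), so compound 4 is estimated at 60 nM, within 25 nM to 150 nM.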

Compound 4, half-maximal inhibitory concentration: 17 nM
Estimate against measurement, compound 4: 3.5-fold (0.55 log units) above, outside the stated range (below it).
By their numbers in this assay, from the lowest: compounds 1 and 4 (each within the scatter of the next); then compounds 2 and 3 (each within the scatter of the next).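

In this assay, this place does not need an aromatic ring: with 1,1-dioxothian-4-yl in place of pyridin-3-yl, the result is (a 1.1-fold higher number from compound 1 to compound 4 (0.05 log units; within the scatter)). The two oxygens on the ring sulfur count for a lot here, as the step is (a 4.1-fold lower number from compound 3 to compound 4 (0.61 log units; beyond the scatter)), and the same ring also separates from piperidin-4-yl (a 2.1-fold lower number from compound 2 to compound 4 (0.33 log units; beyond the scatter)). No measurement at hand says why these rings differ. Still open, as far as these compounds go, is whether an open-chain methylsulfonyl group, or a longer chain carrying the same ring, would keep the number of compound 4.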